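Aryl Amide in Place of Benzyl Amide on the Methoxy Core

The compounds below may be only part of what the source reports. "The series", "measured", "known", "first", "only" and "open" are said of these compounds alone.

Measured compounds:
compound 1 `COc1ccc2c(=O)c(/C=C/C(=O)NCc3cccc(F)c3)coc2c1` gives 28600 nM
compound 2 `O=C(/C=C/c1coc2cc(O)ccc2c1=O)NCc1ccc(F)cc1` gives only a limit, > 100000 nM
compound 3 `Cc1ccccc1NC(=O)/C=C/c1coc2cc(O)ccc2c1=O` gives 9320 nM

In a functional assay (QGY7701 cells, Homo sapiens) for inhibition, read by MTT assay, with a stated time of 48 h (a higher number here means a weaker inhibitor, a lower number a stronger inhibitor), compound 1 has the highest of the two numbers, with compound 3 the nearer one. Compound 4 `COc1ccc2c(=O)c(/C=C/C(=O)Nc3ccc(Cl)cc3)coc2c1` differs from compound 1 in one place: 4-chlorophenyl in place of 3-fluorobenzyl on an amide-type nitrogen. For the measured compounds named here, the only measured step that bears on this swap of a benzyl for a directly attached phenyl is an at least 10-fold lower number from compound 2 to compound 3 (1.03 log units; beyond the scatter). Compound 4 is therefore expected to give a lower number than compound 1, a step estimated at a 5.7-fold lower number from compound 1 to compound 4 (0.76 log units; beyond the scatter). Compound 4 is estimated at 5000 nM, within 1500 nM to 20000 nM.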

Compound 4, half-maximal inhibitory concentration: > 100000 nM
Compound 4 was reported as a limit; the forecaster's own chance of this, stated with the estimate: 5%; at least 20-fold (1.30 log units) between middle value and limit.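

In this assay, compound 4 gives > 100000 nM, which is a limit and not a number: the limit of > 100000 nM in this assay, at which 2 of the 4 values shown sit. Replacing 3-fluorobenzyl with 4-chlorophenyl on the amide-type nitrogen gives an at least 3.4-fold higher number from compound 1 to compound 4 (0.54 log units; beyond the scatter), opposite in direction to an at least 10-fold lower number from compound 2 to compound 3 (1.03 log units; beyond the scatter). A phenyl ring attached directly to this nitrogen therefore does not by itself give a lower number.

The two steps differ in both the core and the ring substituent, so the compounds shown cannot tell which of these sets the direction. They also leave open how an amine, a carboxylic acid or a longer chain would read at this nitrogen.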